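Removing a Carboxy Group from a Benzimidazole-type Amidine Series

The source may report more compounds than this note shows. Statements on the series, on what has been measured and on what is new or still open speak of the compounds shown alone.

Of the compounds shown here, three have been measured in an assay on isolated protein for inhibition of serine protease 1 (Bos taurus); on this read-out higher numbers stand for weaker inhibition and lower numbers for stronger inhibition. Compound 1 `CCc1nc2cc(OC3CCN(C(C)=N)CC3)ccc2n1Cc1ccc2ccc(C(=N)N)cc2c1` gives 17 nM in this assay. Compound 2 `CC(=N)N1CCC(Oc2ccc3c(c2)nc(CCC(=O)O)n3Cc2ccc3ccc(C(=N)N)cc3c2)CC1` gives 14 nM, and compound 3 `CC(=N)N1CCC(Oc2ccc3nc(CCC(=O)O)n(Cc4ccc5ccc(C(=N)N)cc5c4)c3c2)CC1` gives 18 nM. Compound 2 and compound 3 are built from the same atoms joined differently; the difference between the two cores is not broken down here. Compound 3 stands nearest to compound 1 and furthest from compound 2, and both of these gaps lie within the usual scatter.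

One structural change recurs in this set. Compound 1 differs from compound 2 by hydrogen in place of carboxy on a saturated chain carbon, two bonds along the chain from an aromatic carbon. The step in this assay was a 1.2-fold higher number from compound 2 to compound 1 (0.08 log units; within the scatter), a change that stays within the scatter. The unmeasured compound 4 `CCc1nc2ccc(OC3CCN(C(C)=N)CC3)cc2n1Cc1ccc2ccc(C(=N)N)cc2c1` differs from compound 3 by exactly the same change, (hydrogen in place of carboxy on a saturated chain carbon, two bonds along the chain from an aromatic carbon), made on the core of compound 3 instead of the core of compound 2.

Among the measured compounds shown here, since the single earlier instance of this change, from compound 2 to compound 1, hardly moved the number, a similar outcome is expected when the same change is made on the core of compound 3, so that the step from compound 3 to compound 4 is estimated at a 1.2-fold higher number from compound 3 to compound 4 (0.07 log units; within the scatter). On that basis compound 4 is expected to give about 21 nM in this assay, with the likely range running from 10 nM to 45 nM, resting on the value of compound 3 18 nM and the step from compound 2 to compound 1.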

Compound 4, inhibition constant: 7.7 nM
Compound 4: middle estimate off by 2.7-fold (0.44 log units), on the high side; measured number below the stated range.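

Replacing carboxy by hydrogen on the core of compound 3 gave a 2.3-fold lower number from compound 3 to compound 4 (0.37 log units; beyond the scatter) in this assay, so on this core the change is linked to a modest strengthening of inhibition. This rests on a single step on each of two cores, which is enough to separate the two cores in this one assay, but it does not explain why they part ways and sets no rule for any further core in the series. What the pair of steps does show is that the outcome of this change on one core could not simply be carried over to the other, since the size and direction of the two steps do not agree: the same change on two cores in this assay, a 1.2-fold higher number (0.08 log units; within the scatter) from compound 2 to compound 1 and a 2.3-fold lower number (0.37 log units; beyond the scatter) from compound 3 to compound 4, 2.8-fold (0.45 log units) apart, beyond the scatter of two such steps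

The compounds shown leave open whether this split between the cores is tied to the carboxylic acid itself or would also appear with other ends on the chain, such as an amide, an amine or a longer chain carrying a carboxylic acid. They also leave open whether the same split would appear with the ethyl and 2-carboxyethyl pairs on a further core, or on a different protease.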